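Swapping the Carboxyphenyl Amide for a Hydroxyethyl Amide

The source may report more compounds than this note shows. Statements on the series, on what has been measured and on what is new or still open speak of the compounds shown alone.

Going by the values given here, compound 1 `C=C(CC)C(=O)c1ccc(OCC(=O)Nc2cccc(C(=O)O)c2)c(Cl)c1Cl` gives 20600 nM in a functional assay on CLL cells (Homo sapiens) for cytotoxicity, read by MTT assay, with a stated time of 48 h (a higher number here means that more compound is needed for the effect, a lower number that less compound is needed), the highest of the two numbers known so far. Its nearest neighbour, compound 2 `C=C(CC)C(=O)c1ccc(OCC(=O)Nc2ccc(Cl)c(C(=O)O)c2)c(Cl)c1Cl`, gives 15900 nM in this assay. Among the compounds with values here, the single measured step, a 1.3-fold lower number from compound 1 to compound 2 (0.11 log units; within the scatter), is chloro in place of hydrogen on an aromatic carbon and lies within the scatter. Compound 3 `C=C(CC)C(=O)c1ccc(OCC(=O)NCCO)c(Cl)c1Cl` is not yet measured; it differs from compound 1 by 2-hydroxyethyl in place of 3-carboxyphenyl on an amide-type nitrogen. Within the data shown here, no measured step touches the amide-type nitrogen, and the one step known concerns only a ring substituent and was within the scatter, so the data give no direction for this change. Compound 3 is therefore expected to stay close to compound 1, a step of a 1.2-fold higher number from compound 1 to compound 3 (0.08 log units; within the scatter) with a wide range. The estimate for compound 3 in this assay is 25000 nM, between 8000 nM and 80000 nM.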

Compound 3, half-maximal effective concentration: > 25000 nM
Compound 3 gave a limit, no number; the forecaster's own chance of this, stated with the estimate: 10%; the middle value lies on the limit itself.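

Compound 3 gives > 25000 nM in this assay, which is a limit of the assay and not a number. The earlier step concerned only a ring substituent, whereas an at least 1.2-fold higher number from compound 1 to compound 3 (0.08 log units; that floor lies within the scatter) is the only one that touches the amide-type nitrogen, and with 2-hydroxyethyl there, carrying no ring, the assay yields no number at all. As far as these compounds go, the step gives only a floor, so the data do not separate compound 3 from compound 1, and the real size of this change remains unknown.

The 3-carboxyphenyl group leaves as a whole, so the compounds shown cannot tell the part played by its aromatic ring from that of its carboxylic acid. A plain phenyl group on this nitrogen, or a carboxylic acid carried on a short open chain, would pull those two parts apart.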